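Trimming the Hydroxyalkyl End of Compound 2

A few compounds are considered here, and "the series" means these few. Any claim that something is new, unique, unknown or untested is made for them only; others in the source may bear on it.

Of the compounds shown here, three sharing a core have been measured in a physicochemical assay for inhibition, read by spectrophotometry, tested at 100 uM; a higher number here means more inhibition at the concentration tested (going by the name of the read-out), a lower number less inhibition. Compound 1 `COc1ccc(C(=NNC(=O)NNC(=O)NCCCC(C)Nc2cc(OC)cc3cccnc23)c2ccc(OC)cc2)cc1` gives 82%, and compound 3 `COc1cc(NC(C)CCCNC(=O)NNC(=O)N(C)C(c2ccccc2)c2ccccc2)c2ncccc2c1` gives 69%. Compound 2 `COc1cc(NC(C)CCCNC(=O)NNC(=O)N(CCO)CCO)c2ncccc2c1` gives 43%, the lowest of the three numbers: its nearest neighbour is compound 3, whose value lies higher by a margin beyond the scatter, and compound 1 stands further off, also beyond the scatter.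

Compound 4 `COc1cc(NC(C)CCCNC(=O)NNC(=O)NCCCO)c2ncccc2c1` has not yet been measured. It differs from compound 2 at one place: (3-hydroxypropyl)amino in place of bis(2-hydroxyethyl)amino on a carbonyl carbon. Among the compounds with values here, no pair of measured compounds differs in exactly one place, so no measured step shows how a change of this kind plays out, and compounds 1 and 3 are built differently at that end. Compound 4 is therefore expected to stay close to compound 2, with the estimated step of a number 4 percentage points higher from compound 2 to compound 4 (within the scatter) expected to remain within the scatter in either direction. For compound 4 the value in this assay is estimated at 47%, within a range from 30% to 64%.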

Compound 4, a percentage reported as inhibition, at one concentration (the size of the read-out at that concentration, not a potency): 45%
The estimate for compound 4 lay 2 percentage points above the measured number; the measured number falls inside the stated range.
By their numbers in this assay, from the lowest: compounds 2 and 4 (each within the scatter of the next); then compound 3; then compound 1.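

In this assay, within the data shown here, putting (3-hydroxypropyl)amino in place of bis(2-hydroxyethyl)amino on a carbonyl carbon gives a number 2 percentage points higher from compound 2 to compound 4 (within the scatter) and is the first step that can be read at this position. The change takes the group from 7 heavy atoms to 5 and from 2 hydrogen-bond acceptors to 1, with 2 hydrogen-bond donors on both sides, and the read-out does not move beyond the scatter. Nothing available explains why the two compounds read alike.

On these data alone, it remains open whether a different kind of group on this carbonyl carbon, such as a carboxylic acid, a primary amine or a longer hydroxyalkyl chain, would shift the number beyond the scatter. As far as these compounds go, it is also open whether a single 2-hydroxyethyl chain on that nitrogen would read like these two compounds.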